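Replacing a piperidine with an aryl ether: expected half-life

The compounds below may be only part of what the source reports. "The series", "measured", "known", "first", "only" and "open" are said of these compounds alone.

Measured so far:
- compound 1 `COc1ccc2[nH]c(C(=O)N3CC(=O)N(Cc4ccccc4)[C@@H](CCc4ccccc4)C3)cc2c1`: 0.167 h
- compound 2 `COc1ccc2[nH]c(C(=O)N3CC(=O)N(Cc4ccccc4)[C@@H](CN4CCC5(CC4)CC5)C3)cc2c1`: 0.867 h
- compound 3 `COc1ccc2[nH]c(C(=O)N3CC(=O)N(Cc4ccccc4)[C@@H](N4[C@H](C)CCC[C@@H]4C)C3)cc2c1`: 0.112 h

These three compounds share the same core and differ only in the group on a saturated ring carbon of the central ring. In an ADME assay on microsomes from liver (Homo sapiens) for metabolic stability, with a stated time of 30 min, tested at 1 uM (a lower number here means that the compound disappears faster, a higher number that the compound lasts longer), compound 3 gives the lowest of the three numbers, though its gap to compound 1 is small: a 1.5-fold lower number from compound 1 to compound 3 (0.17 log units; within the scatter). The gap to compound 2 is larger: a 7.7-fold lower number from compound 2 to compound 3 (0.89 log units; beyond the scatter).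

Compound 4 `COc1ccc2[nH]c(C(=O)N3CC(=O)N(Cc4ccccc4)[C@@H](COc4ccc(F)cc4)C3)cc2c1` is the next change from compound 3: (4-fluorophenoxy)methyl in place of 2,6-dimethylpiperidin-1-yl on a saturated ring carbon.

Within the data shown here, two measured steps bear on this. Compound 4 resembles compound 1 most closely, since both carry an aromatic ring on a short saturated linker; the step from that kind of group to the dimethylpiperidinyl group was within the scatter (a 1.5-fold lower number from compound 1 to compound 3 (0.17 log units; within the scatter)). Among the measured compounds shown here, the one step that moved the number clearly was the one involving compound 2, which carries a different kind of group not present in compound 4 (a 7.7-fold lower number from compound 2 to compound 3 (0.89 log units; beyond the scatter)). The expected result for compound 4 in this assay is therefore a small rise over compound 3, of about a 2.2-fold higher number from compound 3 to compound 4 (0.35 log units; beyond the scatter), and it may well fall within the scatter. The half-life of compound 4 is estimated at 0.25 h, with a likely range from 0.1 h to 0.6 h.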

Compound 4, half-life: 0.317 h
The estimate for compound 4 lay 1.3-fold (0.10 log units) below the measured number; measured number inside the range.
By their numbers in this assay, from the lowest: compounds 3, 1 and 4 (each within the scatter of the next, the first and the last beyond it); then compound 2.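

In this assay, among these compounds, the (4-fluorophenoxy)methyl group is the first aromatic group at this saturated ring carbon to separate clearly from the 2,6-dimethylpiperidin-1-yl group (a 2.8-fold higher number from compound 3 to compound 4 (0.45 log units; beyond the scatter)). That separation is limited, however: with the aromatic ring kept on a short chain, putting 4-fluorophenoxy in place of benzyl on the saturated chain carbon gives a step that stays inside the usual scatter (a 1.9-fold higher number from compound 1 to compound 4 (0.28 log units; within the scatter)), so these two groups cannot be told apart here. The group of compound 2, which has a three-membered carbon ring and a six-membered ring holding one nitrogen, still gives a clearly longer half-life than the fluorophenoxy group on the same chain carbon (a 2.7-fold lower number from compound 2 to compound 4 (0.44 log units; beyond the scatter)), showing that the choice of group on this chain carbon can still move the read-out beyond the scatter.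

Nothing shown here explains why any of these half-lives differ. As far as these compounds go, it also remains open how a plain phenoxy group without the fluorine, or a morpholine on the same chain carbon, would behave, so the separate contributions of the fluorine atom and of the ring nitrogen cannot yet be judged.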